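Chloro to bromo: one step from compound 1

The source may report more compounds than this note shows. Statements on the series, on what has been measured and on what is new or still open speak of the compounds shown alone.

Compound 1 `Clc1ccc(NCc2cn(-c3ccccc3)nc2-c2ccc(Cl)cc2)cc1` is the reference point of these notes. Among the compounds with values here, in a functional assay on MCF7 cells (Homo sapiens) for antiproliferative activity, read by MTT assay, with a stated time of 48 h (a lower number here means a stronger inhibitor, a higher number a weaker inhibitor), compound 1 gives 2280 nM, the lowest of the two numbers measured so far. Compound 2 `Cc1ccc(NCc2cn(-c3ccccc3)nc2-c2ccc(Cl)cc2)cc1` gives 3110 nM in the same assay. Within the data shown here, the one measured step, a 1.4-fold higher number from compound 1 to compound 2 (0.13 log units; within the scatter), is the methyl in place of chloro on an aromatic carbon, and it stays within the scatter. Compound 3 `Clc1ccc(NCc2cn(-c3ccccc3)nc2-c2ccc(Br)cc2)cc1` differs from compound 1 in a single place: bromo in place of chloro on an aromatic carbon. Among the measured compounds shown here, no measured step exchanges one halogen for another, so the bearing of the methyl step on this change is indirect; all it shows is that a small substituent change on an aromatic carbon did not move the number beyond the scatter. The expectation for compound 3 is therefore no step beyond the scatter, a 1.1-fold lower number from compound 1 to compound 3 (0.06 log units; within the scatter). The estimated value for compound 3 is 2000 nM, with a range from 1000 nM to 4200 nM.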

Compound 3, half-maximal inhibitory concentration: 4150 nM
Estimate against measurement, compound 3: 2.1-fold (0.32 log units) below, within the range that was stated.
By their numbers in this assay, from the lowest: compounds 1, 2 and 3 (each within the scatter of the next).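

In this assay, the change from 4-chlorophenyl to 4-bromophenyl gives a 1.8-fold higher number from compound 1 to compound 3 (0.26 log units; within the scatter). Within the data shown here, this is the first measured step at this position, on the aromatic ring that stays the same in compound 2, and the first exchange of one halogen for another. Like the methyl step on the other chloro-bearing ring, a 1.4-fold higher number from compound 1 to compound 2 (0.13 log units; within the scatter), it stays within the scatter, so neither of the two positions has yet shown a step beyond it. No supporting data bear on this result.

Open, on these data alone, is whether any other group at this position, such as fluoro, methoxy, an amine or a carboxylic acid, gives a step beyond the scatter. Also open, as far as these compounds go, is whether bromo on the other ring behaves as it does here.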